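Carbamate to urea on the benzyl side of the series

The compounds below may be only part of what the source reports. "The series", "measured", "known", "first", "only" and "open" are said of these compounds alone.

Three compounds share a core built around a sulfamide-bearing side chain and an amide to a thiazole-type ring. In an assay for inhibition of protein deacetylase HDAC6 (Homo sapiens) (a lower number here means a stronger inhibitor, a higher number a weaker inhibitor), compound 1 `NS(=O)(=O)NCCCC[C@H](NC(=O)OCc1ccccc1)C(=O)Nc1nc2ccccc2s1` gives 190 nM. Compound 2 `CCOC(=O)c1csc(NC(=O)[C@H](CCCCNS(N)(=O)=O)NC(=O)OCc2ccccc2)n1` gives 580 nM in this assay, and compound 3 `NS(=O)(=O)NCCCC[C@H](NC(=O)OCc1ccc(Cl)cc1)C(=O)Nc1nc(-c2ccccc2)cs1` gives 530 nM. Compound 3 thus stands second highest of the three numbers; its value and that of compound 2 lie within the scatter of each other, while the gap to compound 1 is beyond it.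

For the measured compounds named here, the one measured step that changes a single place, a 3.1-fold higher number from compound 1 to compound 2 (0.48 log units; beyond the scatter), concerns the ring on the amide nitrogen and leaves the benzyl carbamate untouched.

Compound 4 `NS(=O)(=O)NCCCC[C@H](NC(=O)NCc1ccc(F)cc1)C(=O)Nc1nc(-c2ccccc2)cs1` differs from compound 3 by (4-fluorobenzyl)amino in place of (4-chlorobenzyl)oxy on a carbonyl carbon, on a carbonyl carbon whose other neighbour is an amide-type nitrogen. Going by the values given here, no measured pair shows a change at this position, so nothing calibrates this step. Among the compounds with values here, with no direct precedent, the expectation for compound 4 in this assay is a step of a 1.1-fold lower number from compound 3 to compound 4 (0.03 log units; within the scatter), that is, no shift beyond the scatter. Compound 4 is therefore estimated at 500 nM, with a range from 200 nM to 1300 nM.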

Compound 4, half-maximal inhibitory concentration: 370 nM
The estimate for compound 4 lay 1.4-fold (0.13 log units) above the measured number; the range from low to high includes it.
By their numbers in this assay, from the lowest: compounds 1, 4, 3 and 2 (each within the scatter of the next, the first and the last beyond it).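

In this assay this position gets its first reading, a 1.4-fold lower number from compound 3 to compound 4 (0.16 log units; within the scatter), so (4-fluorobenzyl)amino can stand in place of (4-chlorobenzyl)oxy on a carbonyl carbon with no shift beyond the scatter. The leaving group carries a hydrogen-bond acceptor and the entering group a hydrogen-bond donor, and within this pair that exchange, made together with chlorine giving way to fluorine, does not move the number beyond the scatter. No measurement at hand bears on the reason for this outcome.

Oxygen to nitrogen and chlorine to fluorine arrive in a single step, so their separate contributions remain unresolved, and a (4-chlorobenzyl)amino group on the same carbonyl carbon would separate them. Also open, going by these compounds, are whether this tolerance extends to an unsubstituted benzylamino group or a longer chain such as 2-phenylethylamino, and whether it holds when the phenyl-bearing ring of compound 3 gives way to the 1,3-benzothiazol-2-yl group of compound 1.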